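The compounds below may be only part of what the source reports. "The series", "measured", "known", "first", "only" and "open" are said of these compounds alone.

Measured so far:
- Compound 1, `Oc1ccc(-c2nc3c(NC4CCCC4)cccn3c2-c2ccnc(NC3CCCC3)n2)cc1`: in an ADME assay on Vero cells (Chlorocebus sabaeus) for cytotoxicity (a lower number here means that less compound is tolerated, a higher number that more compound is tolerated), compound 1 gives > 40000 nM, which is a limit of the assay and not a number.
- Compound 2, `C=CCOc1ccc(-c2nc3c(NC4CCCC4)cccn3c2-c2ccnc(NC3CCCC3)n2)cc1`: in this assay compound 2 gives > 40000 nM, again a limit of the assay.

Compound 2 therefore stands only at a limit in this assay; no number is known for it. Compound 3, `c1cc(NC2CCCC2)c2nc(-c3ccc(OCC4CC4)cc3)c(-c3ccnc(NC4CCCC4)n3)n2c1`, differs from compound 2 by cyclopropyl in place of vinyl on a saturated chain carbon bound to an oxygen on an aromatic ring. Among the measured compounds shown here, the single measured step, a step that the two limits leave unreadable from compound 1 to compound 2, concerns the same oxygen substituent but gives no readable size. What the series shows so far is the limit of > 40000 nM in this assay, at which 2 of the 2 values shown sit. With both measured values at the limit, nothing supports a step in either direction beyond the scatter, and compound 3 is expected to stay at the limit as well, a number no higher from compound 2 to compound 3 (the limit leaves the size open). The estimate for compound 3 in this assay is 40000 nM, with a range from 20000 nM to 80000 nM.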

Compound 3, half-maximal cytotoxic concentration: > 40000 nM
Compound 3: only a limit was reported; the forecaster's own chance of this, stated with the estimate: 85%; the middle value sits exactly at the limit.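

No step can be read among compound 1, compound 2 and compound 3 in this assay: the limit of > 40000 nM in this assay, at which 3 of the 3 values shown sit.

The compounds shown leave open whether hydrogen, allyl and cyclopropylmethyl on the oxygen differ at all in this assay, since none of the three has a number there.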